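Cytotoxicity in Human Fibroblasts Across Two Nitroimidazooxazine Cores

This account rests on a few compounds, and the source may have more. Where it says the series, first, only, none or still open, it means among the compounds named here.

Compound 1 `O=[N+]([O-])c1cn2c(n1)OC(COc1cccc(-c3ccc(F)nc3F)n1)CC2` and compound 3 `O=[N+]([O-])c1cn2c(n1)OC(COc1cccc(-c3ccc(F)cc3F)n1)CC2` share one core, while compound 2 `CC1(COc2ccc(-c3ccc(F)nc3F)nc2)CCn2cc([N+](=O)[O-])nc2O1` and compound 4 `CC1(COc2ccc(-c3ccc(F)cc3F)nc2)CCn2cc([N+](=O)[O-])nc2O1` share another; the difference between the two cores is not broken down here. In an ADME assay on MRC5 cells (Homo sapiens) for cytotoxicity, read by resazurin assay, with a stated time of 72 h (a lower number here means a stronger inhibitor, a higher number a weaker inhibitor), compound 1 gives only a limit, > 64000 nM. Compound 3 gives only a limit in this assay, > 64000 nM. Compound 2 likewise gives only a limit in this assay, > 64000 nM. The change 2,4-difluorophenyl in place of 2,6-difluoropyridin-3-yl on an aromatic carbon produces a step that the two limits leave unreadable from compound 1 to compound 3, because of the limit of > 64000 nM in this assay, at which 3 of the 3 values shown sit. From compound 2 to compound 4 the change is 2,4-difluorophenyl in place of 2,6-difluoropyridin-3-yl on an aromatic carbon, the same kind of change, the place now being para to a large group rather than meta to a large group. Compound 4 is expected to give a step that the limit leaves unreadable from compound 2 to compound 4, resting on compound 2 at > 64000 nM and on (the limit of > 64000 nM in this assay, at which 3 of the 3 values shown sit). Compound 4 is therefore estimated at 100000 nM, most likely again only a limit.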

Compound 4, half-maximal inhibitory concentration: > 64000 nM
Compound 4: only a limit was reported; the forecaster's own chance of this, stated with the estimate: 90%; the middle value lies beyond the limit too.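

Compound 4 gives only a limit, so the step from compound 2 to compound 4 cannot be read, because no value in this set falls inside the measurable range: the limit of > 64000 nM in this assay, at which 4 of the 4 values shown sit.

The compounds shown leave open whether 2,4-difluorophenyl and 2,6-difluoropyridin-3-yl differ at all in this assay, and how the two cores compare there.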